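Chloro on the benzyl of compound 3: expected effect

This account rests on a few compounds, and the source may have more. Where it says the series, first, only, none or still open, it means among the compounds named here.

Compound 3 `CC1=C(C(=O)Nc2ccc([N+](=O)[O-])cc2)C(c2ccc(Br)cc2)N=C(SCc2ccccc2)N1` gives 2.1% in a functional assay on the whole organism (artery, strain albino) with Rattus norvegicus as the target, with a stated time of 15 min, at a dose of 10 mg/kg by the oral route; on this read-out lower numbers stand for less inhibition and higher numbers for more inhibition at the one dose given (going by the name of the read-out); this sits within the scatter of compound 1 `CC1=C(C(=O)Nc2ccc(Br)cc2)C(c2ccc(Cl)cc2Cl)N=C(SCc2ccccc2Cl)N1` at 3.1% and of compound 2 `CC1=C(C(=O)Nc2ccc(Br)cc2)C(c2ccc(Cl)cc2Cl)N=C(SCc2ccc(F)cc2)N1` at 3.6%, so all three read as flat at the dose given. Compound 4 `CC1=C(C(=O)Nc2ccc([N+](=O)[O-])cc2)C(c2ccc(Br)cc2)N=C(SCc2cccc(Cl)c2)N1` differs from compound 3 by chloro in place of hydrogen on an aromatic carbon. For the measured compounds named here, the only measured step that touches the same benzyl region is a number 0.5 percentage points higher from compound 1 to compound 2 (within the scatter), and it stayed within the scatter. On that basis no step beyond the scatter is expected in this assay for compound 4, with a number 1.4 percentage points higher from compound 3 to compound 4 (within the scatter) as the expected step. Compound 4 is therefore estimated at 3.5%, with a range from 0% to 12%.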

Compound 4, a percentage reported as inhibition, in the whole organism at one dose (the size of the read-out at that dose, not a potency): 2.1%
Estimate against measurement, compound 4: 1.4 percentage points above, within the range that was stated.
By their numbers in this assay, from the lowest: compounds 3, 4, 1 and 2 (each within the scatter of the next).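

In this assay, the change from benzylsulfanyl to (3-chlorobenzyl)sulfanyl gives no change at the digits printed from compound 3 to compound 4 (within the scatter). Unlike the earlier step, which exchanged one halogenated benzyl for another, this sets chloro directly against hydrogen on the ring and leaves the reading flat. No evidence bears on this result.

From the compounds shown here alone, with all four compounds within the scatter at a single dose, it remains open whether any group at this position can move the reading. An amine or a carboxylic acid on this ring, or a longer chain in place of benzyl, would test that.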